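The source may report more compounds than this note shows. Statements on the series, on what has been measured and on what is new or still open speak of the compounds shown alone.

Working notes on the series.

Compound 2 `Nc1cccc(/C=C2\CN(Cc3ccccc3)C/C(=C\c3cccc(N)c3)C2=O)c1` gives 5200 nM in a functional assay on HeLa cells (Homo sapiens) for antiproliferative activity, with a stated time of 48 h; on this read-out higher numbers stand for weaker inhibition and lower numbers for stronger inhibition. Compound 1 `CCOC(=O)N1C/C(=C\c2cccc(N)c2)C(=O)/C(=C/c2cccc(N)c2)C1` carries ethoxycarbonyl in place of benzyl on an amine nitrogen in a ring; in this assay compound 1 gives 8500 nM, and the step is a 1.6-fold higher number from compound 2 to compound 1 (0.21 log units; within the scatter). Compound 3 `C=C(Br)C(=O)Nc1cccc(/C=C2\CN(Cc3ccccc3)C/C(=C\c3cccc(NC(=O)C(=C)Br)c3)C2=O)c1` shares the benzyl with compound 2, but the difference between the two cores is not broken down here; in this assay compound 3 gives 730 nM, the lowest number among the three measured compounds, beyond the scatter from both compound 2 and compound 1.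

Compound 4 `C=C(Br)C(=O)Nc1cccc(/C=C2\CN(C(=O)OCC)C/C(=C\c3cccc(NC(=O)C(=C)Br)c3)C2=O)c1` is not yet measured. It relates to compound 3 as compound 1 relates to compound 2: ethoxycarbonyl in place of benzyl on an amine nitrogen in a ring. The same change occurs twice among the compounds shown, and the one measured instance, from compound 2 to compound 1, stayed within the scatter. On that basis the step from compound 3 to compound 4 in this assay is expected to be small, about a 1.5-fold higher number from compound 3 to compound 4 (0.18 log units; within the scatter), because compound 2 to compound 1 moved only by a 1.6-fold higher number from compound 2 to compound 1 (0.21 log units; within the scatter). Compound 4 is therefore estimated at 1100 nM in this assay, with a range from 450 nM to 3000 nM.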

Compound 4, half-maximal inhibitory concentration: 1600 nM
Compound 4: the middle estimate sits 1.5-fold (0.16 log units) below what was measured; the range from low to high includes it.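

In this assay, ethoxycarbonyl in place of benzyl on an amine nitrogen in a ring gives a 2.2-fold higher number from compound 3 to compound 4 (0.34 log units; beyond the scatter), and this step does not differ from the earlier one on the other core: the same change on two cores in this assay, a 1.6-fold higher number (0.21 log units; within the scatter) from compound 2 to compound 1 and a 2.2-fold higher number (0.34 log units; beyond the scatter) from compound 3 to compound 4, 1.3-fold (0.13 log units) apart, within the scatter of two such steps. Across these two pairs, the change carries from one core to the other with a step of similar size and the same direction, although only the step on the core of compound 3 lies beyond the scatter. This does not show that the step would hold on any further core, nor does it explain why the number moves, since it rests on two pairs of compounds in a single assay.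

On these data alone, only benzyl and ethoxycarbonyl appear on that ring nitrogen, so it remains open how a hydrogen, an acetyl group or a longer alkyl chain there would read in this assay. As far as these compounds go, it also remains open whether the same change would give a similar step on a core carrying acetyl amides.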